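Triazole-linked nucleosides: cytotoxicity outlook for compound 3

A few compounds are considered here, and "the series" means these few. Any claim that something is new, unique, unknown or untested is made for them only; others in the source may bear on it.

The series is read in a functional assay on LAC cells (Homo sapiens) for cytotoxicity, read by MTT assay, with a stated time of 72 h; a higher number here means that more compound is needed for the effect, a lower number that less compound is needed. Compound 1, `CCOC(=O)c1cn(C[C@H]2O[C@@H](n3ccc(=O)[nH]c3=O)[C@H](SCC)[C@@H]2SCC)nn1`, carries an ethoxycarbonyl triazole on the sugar. In this assay compound 1 gives only a limit, >= 100000 nM. Compound 2, `CCS[C@@H]1[C@H](SCC)[C@@H](Cn2cc(-c3ccc(C)cc3)nn2)O[C@H]1n1cc(C)c(=O)[nH]c1=O`, carries a 4-methylphenyl triazole instead and a methyl on the pyrimidine. In this assay compound 2 likewise gives only a limit, >= 100000 nM. Both values shown thus sit at the same place, (the limit of >= 100000 nM in this assay, at which 2 of the 2 values shown sit), so compound 2 cannot be ranked against compound 1; neither shows measurable cytotoxicity within the concentration range tested.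

Compound 3, `CCOC(=O)c1cn(C[C@H]2O[C@@H](n3cc(C)c(=O)[nH]c3=O)[C@H](SCC)[C@@H]2SCC)nn1`, is the next member. It differs from compound 2 by ethoxycarbonyl in place of 4-methylphenyl on an aromatic carbon. Among the measured compounds shown here, no measured step changes the aromatic carbon of the five-membered ring bearing three nitrogen, so there is nothing to draw on for the size of the step; compound 1 already shows the ethoxycarbonyl triazole at the limit. The expectation is therefore no step beyond the scatter, a number no higher from compound 2 to compound 3 (the limit leaves the size open), and a further limit. Compound 3 is expected at 100000 nM, estimated between 50000 nM and 200000 nM.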

Compound 3, half-maximal effective concentration: >= 100000 nM
Compound 3: only a limit was reported; the forecaster's own chance of this, stated with the estimate: 85%; the middle value sits exactly at the limit.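

In this assay compound 3 gives only a limit, >= 100000 nM. Among the compounds shown here, no step from compound 1 or compound 2 to compound 3 can be read, as all three compounds stand at the same place: the limit of >= 100000 nM in this assay, at which 3 of the 3 values shown sit. The compounds shown leave open which change to the shared core, if any, would give a measurable value in this series.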